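Working notes: from compound 2 to compound 4

The compounds below may be only part of what the source reports. "The series", "measured", "known", "first", "only" and "open" are said of these compounds alone.

Measured so far:
compound 1 `COc1ccc(N2CCN(C(=S)SCc3ccc(C(=O)Nc4ccccc4N)cc3)CC2)cc1` — 52.3%
compound 2 `Nc1ccccc1NC(=O)c1ccc(CSC(=S)N2CCc3cc(Cl)ccc32)cc1` — 65.1%
compound 3 `Nc1ccccc1NC(=O)c1ccc(CSC(=S)N2CCN(c3ccccc3F)CC2)cc1` — 59.2%

All three share the same core and were read in a functional assay on HeLa cells (Homo sapiens) for antiproliferative activity, read by CCK-8 assay, with a stated time of 72 h, tested at 8 uM; a lower number here means a weaker effect, a higher number a stronger effect of the compound at the concentration tested. Compound 2 shows the highest of the three numbers; its nearest neighbour is compound 3, which sits lower by an amount within the scatter, while compound 1 sits furthest away, lower by an amount beyond the scatter. Compound 2 is therefore not set apart from compound 3 by these data.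

Among the measured compounds shown here, the only step measured within one change is a number 6.9 percentage points higher from compound 1 to compound 3 (within the scatter), a swap of the aryl group on the amine nitrogen in a ring that left the number essentially where it was.

Compound 4 `CN(Cc1ccncc1)C(=S)SCc1ccc(C(=O)Nc2ccccc2N)cc1` is not yet measured. It differs from compound 2 as follows: methyl((pyridin-4-yl)methyl)amino in place of 5-chloro-2,3-dihydro-1H-indol-1-yl on a thiocarbonyl carbon. For the measured compounds named here, this removes the ring amine altogether in favour of an open-chain amine, a kind of change that no measured step covers; the one step available only shows that changing the aryl on a ring amine moves little. The expectation for compound 4 in this assay is therefore anchored on compound 2 with a wide range, and with no direction beyond the scatter claimed.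

The estimate for compound 4 is 55%, expected to fall between 38% and 70%. This corresponds to an expected step of a number 10.1 percentage points lower from compound 2 to compound 4 (beyond the scatter).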

Compound 4, a percentage reported as inhibition, at one concentration (the size of the read-out at that concentration, not a potency): 72.7%
The estimate for compound 4 lay 17.7 percentage points below the measured number; the measured number lies above the stated range.
By their numbers in this assay, from the lowest: compounds 1, 3, 2 and 4 (each within the scatter of the next, the first and the last beyond it).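

In this assay the place on the thiocarbonyl carbon, whose other neighbour is sulfur, now carries an open-chain amine as well as ring amines, with a number 7.6 percentage points higher from compound 2 to compound 4 (within the scatter) on exchanging 5-chloro-2,3-dihydro-1H-indol-1-yl for methyl((pyridin-4-yl)methyl)amino. The earlier compounds shown here showed only ring amines here, so this step adds that, at this one test concentration, the read-out does not depend on a ring containing the amine nitrogen, nor on the chlorine of the leaving group. No measurement available here explains this result.

Going by these compounds, what remains open is which part of methyl((pyridin-4-yl)methyl)amino carries the read-out, since the ring nitrogen, the methyl group and the open chain all enter in a single exchange. Dimethylamino, which has no ring, and methyl(benzyl)amino, which has a phenyl ring in place of pyridin-4-yl, would separate these contributions at this place, and a full concentration series would be needed to go beyond these single-concentration readings, which give only the size of the effect at that concentration.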